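The source may hold more compounds than are shown below. What is called first, only, known or untested is meant among the compounds shown, and "the series" means these compounds.

Working notes on the series built on the core of compound 3 `COc1ccc(CN2CCC(C(=O)Nc3cc(Cl)c(N)cc3OC)CC2)cc1`. In a functional assay on the whole organism for antagonist activity, with Mus musculus as the target (a lower number here means that less compound is needed, a higher number that more compound is needed for the effect), compound 3 gives 0.9 mg/kg, the only number shown among the three measured compounds. Compound 1 `CCCCCCCN1CCC(C(=O)Nc2cc(Cl)c(N)cc2OC)CC1` reaches only a limit of the assay, > 10 mg/kg, in this assay. Compound 2 `CCCN1CCC(C(=O)Nc2cc(Cl)c(N)cc2OC)CC1` likewise gives only a limit, > 10 mg/kg, in this assay. Two of the three values therefore sit at the limit of > 10 mg/kg in this assay, at which 2 of the 3 values shown sit. The measured steps all concern the group on a saturated chain carbon bound to an amine nitrogen in a ring: an at least 11-fold lower number from compound 1 to compound 3 (1.04 log units; beyond the scatter) and an at least 11-fold lower number from compound 2 to compound 3 (1.04 log units; beyond the scatter), while a step that the two limits leave unreadable from compound 1 to compound 2. Compound 3 thus stands at the lowest number shown, separated from both limit-valued compounds by steps beyond the scatter.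

Compound 4 `COc1cc(N)c(Cl)cc1NC(=O)C1CCN(Cc2ccc(O)cc2)CC1` differs from compound 3 in one place: hydrogen in place of methyl on an oxygen on an aromatic ring. Within the data shown here, none of the measured steps touches the oxygen on the aromatic ring; each of them replaces a chain on the saturated chain carbon bound to the amine nitrogen in the ring, so no measured step bears on this change and its size cannot be read from the series. Without a measured guide, a step of no size beyond the scatter is expected, a 1.3-fold higher number from compound 3 to compound 4 (0.12 log units; within the scatter). Compound 4 is accordingly estimated at 1.2 mg/kg in this assay, within 0.4 mg/kg to 4 mg/kg.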

Compound 4, dose for half-maximal effect: > 8 mg/kg
Compound 4: no number, only a limit; the forecaster's own chance of this, stated with the estimate: 15%; middle value at least 6.6-fold (0.82 log units) away from the limit.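

In this assay, among these compounds, methoxy to hydroxy on the 4-methoxybenzyl group comes with an at least 8.8-fold higher number from compound 3 to compound 4 (0.94 log units; beyond the scatter), the first measured step at the oxygen on an aromatic ring. Among the compounds shown here, the earlier steps showed only that the group on the saturated chain carbon bound to the amine nitrogen in the ring matters, whereas this step shows that, with the rest of compound 3 unchanged, replacing one methyl with hydrogen at the far end of that group is enough to move the value beyond the scatter. The full size of the step stays unknown because compound 4 gives no number, only a limit: the limit of > 8 mg/kg in this assay, at which 1 of the 4 values shown sits.

The steps to compound 4 from compound 1 and compound 2 cannot be read, as both ends of each are limits. The compounds shown leave open whether the methyl itself is what counts or whether another group on that oxygen, such as ethyl or a longer chain, or fluorine or an amine in place of the methoxy, would keep the value close to that of compound 3.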